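Hexyl in Place of Isopropyl, Measured Once and Expected Once

The compounds below may be only part of what the source reports. "The series", "measured", "known", "first", "only" and "open" are said of these compounds alone.

Three compounds have numbers in a functional assay on A2780 cells (Homo sapiens) for antiproliferative activity, read by sulforhodamine B assay, with a stated time of 48 h; on this read-out higher numbers stand for weaker inhibition of growth and lower numbers for stronger inhibition of growth:

compound 1, `Cc1ccc(S(=O)(=O)N2CC[C@@H](Cl)C[C@@H]2CC(C)C)cc1`: 36000 nM
compound 2, `CCCCCCC[C@H]1C[C@H](Cl)CCN1S(=O)(=O)c1ccc(C)cc1`: > 100000 nM, which is a limit of the assay and not a number
compound 3, `Cc1ccc(S(=O)(=O)N2CCC(Cl)=CC2CC(C)C)cc1`: 35000 nM

Compound 1 and compound 3 give values within the scatter of each other. The difference between their two cores is not broken down here. Compound 4, `CCCCCCCC1C=C(Cl)CCN1S(=O)(=O)c1ccc(C)cc1`, is not yet measured; it differs from compound 3 by hexyl in place of isopropyl on a saturated chain carbon bound to a saturated ring carbon. The same change, (hexyl in place of isopropyl on a saturated chain carbon bound to a saturated ring carbon), gave an at least 2.7-fold higher number from compound 1 to compound 2 (0.44 log units; beyond the scatter), with compound 2 sitting at the limit of > 100000 nM in this assay, at which 1 of the 3 values shown sits. Since compound 3 gives 35000 nM, close to compound 1, the step from compound 3 to compound 4 is expected to be of at least the same size, a 2.9-fold higher number from compound 3 to compound 4 (0.46 log units; beyond the scatter). Compound 4 is therefore estimated at 100000 nM, between 50000 nM and 300000 nM, and may well be reported only as a limit.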

Compound 4, concentration for 50% growth inhibition: 92000 nM
Compound 4: middle estimate off by 1.1-fold (0.04 log units), on the high side; the range from low to high includes it.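

In this assay, hexyl in place of isopropyl again gives weaker inhibition of growth on the core of compound 3, with a 2.6-fold higher number from compound 3 to compound 4 (0.42 log units; beyond the scatter). The change therefore points the same way on both cores, but this does not show that it has the same size on each: the same change on two cores in this assay, an at least 2.7-fold higher number (0.44 log units; beyond the scatter) from compound 1 to compound 2 and a 2.6-fold higher number (0.42 log units; beyond the scatter) from compound 3 to compound 4; the limit leaves it open whether they differ. Within the data shown here, compound 2 gives > 100000 nM, which is a limit of the assay and not a number, and only the step on the core of compound 3 has a definite size.

The compounds shown leave open how a butyl chain, or a chain carrying an amine or a carboxylic acid, would read on these cores. They also leave open whether the change carries to any further core.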